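The source may hold more compounds than are shown below. What is called first, only, known or untested is meant among the compounds shown, and "the series" means these compounds.

Measured compounds:
- compound 1, `CNc1nccc(N2CC[C@H](NC(=O)Nc3ccc(C)c(Cl)c3)C2)n1`, gives 18.4 nM in an assay on a protein complex for displacement of a labelled ligand from CDK8/Cyclin C (Homo sapiens), read by TR-FRET, with a stated time of 1 h; on this read-out lower numbers stand for stronger inhibition and higher numbers for weaker inhibition
- compound 2, `CCNc1nccc(N2CC[C@H](NC(=O)Nc3ccc(Cl)c(C(F)(F)F)c3)C2)n1`, gives 8.9 nM in this assay

Two compounds share the core of compound 1 and differ at two places at once, the alkyl on the nitrogen on an aromatic ring and the substituents on the aryl of the urea. Compound 2 stands at the lower of the two numbers; compound 1 sits at a number beyond the scatter above it. Going by the values given here, no pair in this set differs in a single place, so the separate weight of either change cannot be read from the data.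

Compound 3, `Nc1nccc(N2CC[C@H](NC(=O)Nc3ccc(Cl)c(C(F)(F)F)c3)C2)n1`, follows compound 2 by one change: hydrogen in place of ethyl on a nitrogen on an aromatic ring. Among the compounds with values here, no single-place step in this set allows a firm prediction of its size. The expectation is for a small step from compound 2 to compound 3, toward weaker inhibition and close to the edge of the scatter, since ethylamino to amino removes the only alkyl on that nitrogen: a 1.7-fold higher number from compound 2 to compound 3 (0.23 log units; within the scatter). On that basis compound 3 is expected at 15 nM, within the range 5 nM to 45 nM.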

Compound 3, half-maximal inhibitory concentration: 42.3 nM
For compound 3 the middle estimate is 2.8-fold (0.45 log units) below the measured one, and the stated range covers the measured number.
By their numbers in this assay, from the lowest: compound 2; then compound 1; then compound 3.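

In this assay, replacing ethylamino with amino while the aryl of the urea stays unchanged gives a 4.8-fold higher number from compound 2 to compound 3 (0.68 log units; beyond the scatter), a step toward weaker inhibition. Going by these compounds alone, this is the first change in the set seen on its own: the earlier pair differed in two places, whereas this step shows that the ethyl on this nitrogen on an aromatic ring carries weight of its own, at least with this urea aryl. Nothing measured here accounts for the size of the step.

From the compounds shown here alone, it remains open what a methyl on this nitrogen would give with the urea aryl of compound 3, and whether a longer chain such as propyl, or a ring such as cyclopropyl, would continue the direction seen from amino to ethylamino or reverse it. Going by these compounds, it is equally open whether the same change would give a step of similar size with the urea aryl of compound 1, which carries methyl and chloro in place of chloro and trifluoromethyl.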